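Moving the methylpiperazine onto a methylene linker

The source may report more compounds than this note shows. Statements on the series, on what has been measured and on what is new or still open speak of the compounds shown alone.

Measured so far in an ADME assay on the whole organism (Mus musculus, strain CD1) for pharmacokinetics, read by LC-MS, using cassette dosing, with a stated time of 24 h, at a dose of 0.4 mg/kg by the intravenous route; a higher number here means faster removal of the compound, a lower number slower removal:
compound 1 `Cc1cn(-c2cc(NC(=O)c3ccc(C)c(Nc4nccc(-c5ccccc5)n4)c3)cc(N3CCNCC3)c2)cn1` gives 52.5 mL/min/kg
compound 2 `Cc1cn(-c2cc(NC(=O)c3ccc(C)c(Nc4nccc(-c5ccccc5)n4)c3)cc(N3CCN(C)CC3)c2)cn1` gives 32.8 mL/min/kg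

Within the data shown here, compound 2 has the lower of the two numbers in this assay, but the only measured step, a 1.6-fold lower number from compound 1 to compound 2 (0.20 log units; within the scatter), lies within the scatter, so the two compounds cannot be told apart. Compound 3 `Cc1cn(-c2cc(CN3CCN(C)CC3)cc(NC(=O)c3ccc(C)c(Nc4nccc(-c5ccccc5)n4)c3)c2)cn1` differs from compound 2 by (4-methylpiperazin-1-yl)methyl in place of 4-methylpiperazin-1-yl on an aromatic carbon. Among the measured compounds shown here, no measured step concerns such a change; the single step known, a 1.6-fold lower number from compound 1 to compound 2 (0.20 log units; within the scatter), alters a different part and stayed within the scatter. On this basis compound 3 is expected to show a 1.0-fold higher number from compound 2 to compound 3 (0.00 log units; within the scatter). The estimate for compound 3 is 33 mL/min/kg, with a range from 18 mL/min/kg to 60 mL/min/kg.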

Compound 3, clearance: 35.7 mL/min/kg
The estimate for compound 3 lay 1.1-fold (0.03 log units) below the measured number; the range from low to high includes it.
By their numbers in this assay, from the lowest: compounds 2, 3 and 1 (each within the scatter of the next).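

In this assay, (4-methylpiperazin-1-yl)methyl in place of 4-methylpiperazin-1-yl on this aromatic carbon gives a 1.1-fold higher number from compound 2 to compound 3 (0.04 log units; within the scatter) and so leaves compound 2 and compound 3 indistinguishable: adding this one carbon produces no readable change. Set against the piperazin-1-yl group, the same new group gives a 1.5-fold lower number from compound 1 to compound 3 (0.17 log units; within the scatter) and so also produces no readable change. Nothing available explains these numbers.

Still open, on these data alone, is whether a longer chain carrying the same ring, or a morpholine ring in its place, would move clearance beyond the scatter.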